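From an Anilino Arm to a Fluorophenoxy Arm

This account rests on a few compounds, and the source may have more. Where it says the series, first, only, none or still open, it means among the compounds named here.

Measured compounds:
compound 1 `O=c1cc(-n2cc(CNc3ccccc3)nn2)c2cc(Br)ccc2o1`: 13200 nM
compound 2 `O=c1cc(-n2cc(COc3ccc(Br)cc3)nn2)c2cc(Br)ccc2o1`: 24500 nM
compound 3 `O=c1cc(-n2cc(COc3ccc(C(F)(F)F)cc3)nn2)c2cc(Br)ccc2o1`: 1620 nM

In a functional assay on A549 cells (Homo sapiens) for antiproliferative activity, read by MTT assay, with a stated time of 48 h (a higher number here means a weaker inhibitor, a lower number a stronger inhibitor), compound 1 holds the second highest of the three numbers. The step of a 1.9-fold higher number from compound 1 to compound 2 (0.27 log units; within the scatter) is within the scatter, while a 15-fold lower number from compound 2 to compound 3 (1.18 log units; beyond the scatter) is large. Compound 4 `O=c1cc(-n2cc(COc3ccc(F)cc3)nn2)c2cc(Br)ccc2o1` differs from compound 1 by 4-fluorophenoxy in place of anilino on a saturated chain carbon bound to an aromatic carbon. The step of a 1.9-fold higher number from compound 1 to compound 2 (0.27 log units; within the scatter) is the closest parallel, as it swaps the same anilino for a phenoxy bearing a halogen, and it stayed within the scatter; the step of a 15-fold lower number from compound 2 to compound 3 (1.18 log units; beyond the scatter) shows that the group on that ring can move the number far. Among the measured compounds shown here, no measured step isolates fluoro against bromo. Compound 4 is therefore expected to sit close to compound 1, a step of a 1.3-fold lower number from compound 1 to compound 4 (0.12 log units; within the scatter). The estimate for compound 4 is 10000 nM, within 2500 nM to 40000 nM.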

Compound 4, half-maximal inhibitory concentration: 850 nM
Compound 4: middle estimate off by 12-fold (1.07 log units), on the high side; the measured number lies below the stated range.
By their numbers in this assay, from the lowest: compounds 4 and 3 (each within the scatter of the next); then compounds 1 and 2 (each within the scatter of the next).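

Replacing anilino with 4-fluorophenoxy gives a 16-fold lower number from compound 1 to compound 4 (1.19 log units; beyond the scatter), whereas the swap to 4-bromophenoxy stayed within the scatter, so the result of this swap depends on the group carried by the phenoxy ring. Fluoro in place of bromo, a change no earlier step isolated, gives a 29-fold lower number from compound 2 to compound 4 (1.46 log units; beyond the scatter). Fluoro in place of trifluoromethyl gives a 1.9-fold lower number from compound 3 to compound 4 (0.28 log units; within the scatter), which leaves those two groups level here.

No measurement shown explains the gap between bromo and these two groups. As far as these compounds go, whether a methoxy group or a nitrile on the phenoxy ring would behave like fluoro remains open.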